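Ether variants on a shared core

The compounds below may be only part of what the source reports. "The series", "measured", "known", "first", "only" and "open" are said of these compounds alone.

Measured so far:
compound 1, `CCOc1c(-c2occ(C)c2CO)ccc2c1CCCC2(C)C`, 22.9 uM
compound 2, `CCOCc1c(C)coc1-c1ccc2c(c1OC)CCCC2(C)C`, 22.9 uM
compound 3, `Cc1coc(-c2ccc3c(c2O)CCCC3)c1C(=O)O`, 57 uM

All three were run in a functional assay on A549 cells (Homo sapiens) for cytotoxicity, read by sulforhodamine B assay, with a stated time of 3 days; on this read-out lower numbers stand for an effect already at smaller amounts and higher numbers for an effect only at larger amounts of compound. Compound 1 stands level with compound 2 at the digits shown, the two together giving the lowest numbers of the three; compound 3 lies furthest from compound 1, its number higher by a step that falls beyond the scatter. The unmeasured compound 4, `COc1c(-c2occ(C)c2CO)ccc2c1CCCC2(C)C`, departs from compound 1 by a single change, (hydrogen in place of methyl on a saturated chain carbon bound to an oxygen on an aromatic ring). Among the measured compounds shown here, no step between measured compounds bears on that change, so the expectation rests on the series alone, and compound 2, which also carries a methoxy on its core and gives 22.9 uM, sits where compound 1 does. The step of a 1.1-fold higher number from compound 1 to compound 4 (0.04 log units; within the scatter) is therefore expected to stay within the scatter, with no direction read into it. Compound 4 is estimated at 25 uM, within 10 uM to 60 uM.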

Compound 4, concentration for half-maximal effect: 23.3 uM
The estimate for compound 4 lay 1.1-fold (0.03 log units) above the measured number, within the range that was stated.
By their numbers in this assay, from the lowest: compounds 1, 2 and 4 (each within the scatter of the next); then compound 3.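

In this assay, ethoxy to methoxy gives a 1.0-fold higher number from compound 1 to compound 4 (0.01 log units; within the scatter), so on a saturated chain carbon bound to an oxygen on an aromatic ring, the methyl can be exchanged for hydrogen with no shift beyond the scatter. A second ether site now has a reading too: hydrogen in place of ethyl on an oxygen on a saturated carbon gives a 1.0-fold higher number from compound 2 to compound 4 (0.01 log units; within the scatter). No measurement at hand accounts for either step.

From the compounds shown here alone, a longer chain such as butoxy on the aromatic oxygen remains open. So does an amine in place of the oxygen on the saturated carbon.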